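Removing the tertiary hydroxy from a bis-azepanylmethyl diphenol

The compounds below may be only part of what the source reports. "The series", "measured", "known", "first", "only" and "open" are said of these compounds alone.

This account follows three compounds measured in a functional assay for inhibition of Voltage-dependent N-type calcium channel subunit alpha-1B (Homo sapiens); a higher number here means a weaker inhibitor, a lower number a stronger inhibitor. Compound 1 `CC(CCC(O)(c1ccccc1)c1ccccc1)(c1ccc(O)cc1)c1ccc(O)c(CN2CCCCCC2)c1` gives 1800 nM. For the measured compounds named here, compound 2 `CC(CCC(O)(c1ccccc1)c1ccccc1)(c1ccc(O)c(CN2CCCCCC2)c1)c1ccc(O)c(CN2CCCCCC2)c1` gives 490 nM, the lowest of the two numbers; the only measured step, a 3.7-fold lower number from compound 1 to compound 2 (0.57 log units; beyond the scatter), separates it from compound 1. Compound 3 `CC(CCC(c1ccccc1)c1ccccc1)(c1ccc(O)c(CN2CCCCCC2)c1)c1ccc(O)c(CN2CCCCCC2)c1` has not yet been measured. The change from compound 2 to compound 3 is hydrogen in place of hydroxy on a saturated chain carbon bound to two aromatic carbons and a saturated chain carbon. Going by the values given here, no measured step bears directly on this change: the one step known, from compound 1 to compound 2, concerns an aromatic substituent and not the saturated chain carbon, so it offers no guide to the size or direction of the effect of losing the hydroxy. In the absence of a relevant precedent, the step of a 1.2-fold lower number from compound 2 to compound 3 (0.09 log units; within the scatter) is estimated to be small, within or close to the usual scatter. On that basis compound 3 is expected to give about 400 nM in this assay, with a range from 150 nM to 1300 nM.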

Compound 3, half-maximal inhibitory concentration: 740 nM
For compound 3 the middle estimate is 1.9-fold (0.27 log units) below the measured one, within the range that was stated.
By their numbers in this assay, from the lowest: compounds 2 and 3 (each within the scatter of the next); then compound 1.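

Replacing the hydroxy with hydrogen on the saturated chain carbon bound to two aromatic carbons and a saturated chain carbon gives, in this assay, a 1.5-fold higher number from compound 2 to compound 3 (0.18 log units; within the scatter), so this assay does not separate the two compounds. For the compounds shown here, this is the first reading at this position, since the earlier step concerned only an aromatic substituent, and it shows that, with both (azepan-1-yl)methyl groups in place, the hydroxy on this carbon is not required for a number in the range of compound 2. No other data accompany this result that could account for it.

Still open, going by these compounds, is whether an amine, a methoxy group or a fluorine on that same carbon would read differently from hydroxy and hydrogen in this functional assay. Also open is whether hydrogen in place of hydroxy would read the same way on compound 1, which lacks one of the two (azepan-1-yl)methyl groups, because the exchange is shown here only on the core that carries both.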